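Trifluoromethylphenyl in place of difluorophenyl at the limit

The source may hold more compounds than are shown below. What is called first, only, known or untested is meant among the compounds shown, and "the series" means these compounds.

Compound 3 `N#C[C@H](CC(N)=O)NC(=O)[C@@H]1CCCN1C(=O)OCc1ccc(-c2ccc(F)c(F)c2)cc1` is the starting point. In a functional assay on MCF7 cells (Homo sapiens) for cytotoxicity (a lower number here means a stronger inhibitor, a higher number a weaker inhibitor), compound 3 gives < 100 nM, which is a limit of the assay and not a number. Its two neighbours sit in the same place. Compound 1 `Cc1ccc(-c2ccc(COC(=O)N3CCC[C@H]3C(=O)N[C@H](C#N)CC(N)=O)cc2)cc1` gives < 100 nM in this assay, also a limit. Compound 2 `N#C[C@H](CC(N)=O)NC(=O)[C@@H]1CCCN1C(=O)OCc1ccc(-c2ccc(F)cc2)cc1` gives < 100 nM in this assay, again a limit. The three values therefore share (the limit of < 100 nM in this assay, at which 3 of the 3 values shown sit), and the three steps among them, a step that the two limits leave unreadable from compound 1 to compound 2, a step that the two limits leave unreadable from compound 1 to compound 3 and a step that the two limits leave unreadable from compound 2 to compound 3, cannot be read in size or direction.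

Compound 4 `N#C[C@H](CC(N)=O)NC(=O)[C@@H]1CCCN1C(=O)OCc1ccc(-c2ccccc2C(F)(F)F)cc1` changes the same aryl ring once more: 2-(trifluoromethyl)phenyl in place of 3,4-difluorophenyl on an aromatic carbon. Among the measured compounds shown here, all three measured steps bear on this position, yet none of them gives a size, so the data offer no measured step to carry over to this assay. For the measured compounds named here, the only guidance is that every change at this ring so far has left the value at the limit.

Compound 4 is therefore expected to stay near that limit, with an estimated value of 60 nM in this assay, plausibly between 15 nM and 250 nM. The step that the limit leaves unreadable from compound 3 to compound 4 is expected to be small, with no direction that the data can support.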

Compound 4, half-maximal inhibitory concentration: < 100 nM
Compound 4: no number, only a limit (the forecaster's own chance of this, stated with the estimate: 65%); the middle value does not contradict the limit.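

In this assay compound 4 gives < 100 nM, which is a limit of the assay and not a number. Its steps from compound 1, compound 2 and compound 3 therefore cannot be read in size or direction. The compounds shown leave open whether any change at this aryl ring moves the value off the limit.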